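Adding Chloro to an Unmeasured Hydroxamic Acid

The source may report more compounds than this note shows. Statements on the series, on what has been measured and on what is new or still open speak of the compounds shown alone.

compound 1 `O=C(/C=C/C=C/CSc1ccccc1)NO` gives "not determined" (no result reported)
compound 2 `O=C(CCCCCC[S+]([O-])c1ccc(Cl)cc1)NO` gives 12300 nM
compound 3 `O=C(CCCCCSc1ccc(Cl)cc1)NO` gives > 25000 nM (a limit)

Compound 1 has no number to stand on: in a functional assay on CCRF-CEM cells (Homo sapiens) for inhibition (on this read-out higher numbers stand for weaker inhibition and lower numbers for stronger inhibition), compound 1 shows "not determined" (no result reported) as its result. Compound 2 reaches 12300 nM on this assay and holds the only exact figure here. Compound 3 sits at > 25000 nM on this scale, which is a limit of the assay and not a number.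

The next compound is compound 4 `O=C(/C=C/C=C/CSc1ccc(Cl)cc1)NO`, still unmeasured. The change is chloro in place of hydrogen on an aromatic carbon, with chloro in place of hydrogen on an aromatic carbon. Among the compounds with values here, no measured pair here shows this change, and compound 1 offers no number to step from. No size or direction of step can therefore be expected with confidence. Compound 2 also carries the chloro group, and its value of 12300 nM in this assay anchors the expectation of weak inhibition. For compound 4 the expected value is about 15000 nM, with an estimated range from 6000 nM to 30000 nM in this test.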

Compound 4, half-maximal inhibitory concentration: 1600 nM
The estimate for compound 4 lay 9.4-fold (0.97 log units) above the measured number, and the stated range ends above it.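

No step can be read for compound 4: compound 1, which differs from it in one place, gives "not determined" (no result reported) in this assay. The compounds shown leave open how much chloro in place of hydrogen changes inhibition on this shared core.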